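This account rests on a few compounds, and the source may have more. Where it says the series, first, only, none or still open, it means among the compounds named here.

Measured so far in an ADME assay on the whole organism for pharmacokinetics, with Homo sapiens as the target; on this read-out higher numbers stand for higher oral bioavailability and lower numbers for lower oral bioavailability:
compound 1 `O=[N+]([O-])c1cccc(NS(=O)(=O)c2ccc3nc(-c4ccccc4)c(-c4ccccc4)nc3c2)c1` gives 85.6%
compound 2 `COc1ccccc1NS(=O)(=O)c1ccc2nc(-c3ccccc3)c(-c3ccccc3)nc2c1` gives 100%
compound 3 `O=[N+]([O-])c1ccc(NS(=O)(=O)c2ccc3nc(-c4ccccc4)c(-c4ccccc4)nc3c2)cc1` gives 87.6%

Compound 2 stands highest of the three numbers, and both steps leading to it lie beyond the scatter: a number 14.4 percentage points higher from compound 1 to compound 2 (beyond the scatter), while a number 12.4 percentage points lower from compound 2 to compound 3 (beyond the scatter). Compound 4 `O=S(=O)(Nc1ccc(O)cc1)c1ccc2nc(-c3ccccc3)c(-c3ccccc3)nc2c1` differs from compound 2 by 4-hydroxyphenyl in place of 2-methoxyphenyl on a sulfonamide nitrogen. Going by the values given here, the two measured departures from compound 2 both replaced the 2-methoxyphenyl with a nitrophenyl and both lowered the number modestly; no measured step exchanges 2-methoxyphenyl for 4-hydroxyphenyl, so the direction of this change is not settled by the data. A modest lowering of similar size is expected, a number 12 percentage points lower from compound 2 to compound 4 (beyond the scatter), with the range extending up to no change beyond the scatter. Compound 4 is therefore estimated at 88%, between 72% and 100%.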

Compound 4, oral bioavailability: 93.9%
Estimate against measurement, compound 4: 5.9 percentage points below; the measured number falls inside the stated range.
By their numbers in this assay, from the lowest: compounds 1, 3, 4 and 2 (each within the scatter of the next, the first and the last beyond it).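

Going by these compounds alone, on the sulfonamide nitrogen, 4-hydroxyphenyl is the first replacement for 2-methoxyphenyl in this assay that stays inside the scatter: a number 6.1 percentage points lower from compound 2 to compound 4 (within the scatter). The same compound also lies within the scatter of both nitrophenyl compounds, with a number 6.3 percentage points higher from compound 3 to compound 4 (within the scatter) and a number 8.3 percentage points higher from compound 1 to compound 4 (within the scatter), so it bridges two compounds that are separated beyond the scatter from compound 2. No measurement on hand accounts for these steps.

On these data alone, whether 2-hydroxyphenyl or 4-methoxyphenyl would separate the group from its place on the ring stays open. So does the outcome with an aminophenyl or a carboxyphenyl on this nitrogen.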